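Cytotoxicity notes on the series around compound 1

The source may report more compounds than this note shows. Statements on the series, on what has been measured and on what is new or still open speak of the compounds shown alone.

Measured so far:
compound 1 `O=[N+]([O-])c1cnc2c(Br)cc(Cl)cn12`: 16200 nM
compound 2 `CSc1ccc(OCc2ncc([N+](=O)[O-])n2C)cc1`: > 200000 nM
compound 3 `O=[N+]([O-])c1cnc2c(Sc3ccc(Cl)cc3)cc(Cl)cn12`: > 7800 nM

Within the data shown here, in an ADME assay on HepG2 cells (Homo sapiens) for cytotoxicity, read by MTT assay, with a stated time of 72 h (a lower number here means that less compound is tolerated, a higher number that more compound is tolerated), compound 1 gives 16200 nM, the only value in the set that is a number. Compound 2 reaches only a limit of the assay, > 200000 nM (the limit of > 200000 nM in this assay, at which 1 of the 3 values shown sits). Compound 3 likewise sits at a limit, > 7800 nM (the limit of > 7800 nM in this assay, at which 1 of the 3 values shown sits). Among the measured compounds shown here, no pair of measured compounds differs in one place, so no measured step is available for guidance.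

Compound 4 `CSCc1nc2c(Br)cc(Cl)cn2c1[N+](=O)[O-]` differs from compound 1 by (methylsulfanyl)methyl in place of hydrogen on an aromatic carbon. The step of a 1.4-fold lower number from compound 1 to compound 4 (0.13 log units; within the scatter) is expected to stay within the usual scatter, with no clear direction. Compound 4 is estimated at 12000 nM in this assay, in a range of 4000 nM to 40000 nM.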

Compound 4, half-maximal cytotoxic concentration: > 15600 nM
Compound 4 was reported as a limit; the forecaster's own chance of this, stated with the estimate: 15%; middle value at least 1.3-fold (0.11 log units) from the limit.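

Among these compounds, compound 4 is reported only as a limit, > 15600 nM, so no step from compound 1 to compound 4 can be read. The compounds shown leave open whether (methylsulfanyl)methyl in place of hydrogen on an aromatic carbon changes the half-maximal cytotoxic concentration at all.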